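Moving a methyl across the ring: a paired comparison

A few compounds are considered here, and "the series" means these few. Any claim that something is new, unique, unknown or untested is made for them only; others in the source may bear on it.

Measured so far:
Compound 1, `Cc1cccc(-n2cc(-c3ccccc3NS(=O)(=O)c3c[nH]c(=O)[nH]c3=O)nn2)c1`: 1870 nM
Compound 2, `Cc1ccc(-n2cc(-c3ccccc3NS(=O)(=O)c3c[nH]c(=O)[nH]c3=O)nn2)cc1`: 2910 nM
Compound 3, `Cc1cccc(-n2cc(-c3cccc(NS(=O)(=O)c4c[nH]c(=O)[nH]c4=O)c3)nn2)c1`: 3550 nM

Of the compounds shown here, three have been tested in a functional assay on A549 cells (Homo sapiens) for antiproliferative activity, read by MTT assay, with a stated time of 24 h; on this read-out lower numbers stand for stronger inhibition and higher numbers for weaker inhibition. Compound 1 has the structure `Cc1cccc(-n2cc(-c3ccccc3NS(=O)(=O)c3c[nH]c(=O)[nH]c3=O)nn2)c1` and gives 1870 nM in this assay. Compound 2, `Cc1ccc(-n2cc(-c3ccccc3NS(=O)(=O)c3c[nH]c(=O)[nH]c3=O)nn2)cc1`, gives 2910 nM. Compound 3, `Cc1cccc(-n2cc(-c3cccc(NS(=O)(=O)c4c[nH]c(=O)[nH]c4=O)c3)nn2)c1`, gives 3550 nM. Among the measured compounds shown here, all three numbers sit close together, and none of the gaps between them reaches beyond the usual scatter of such measurements, so no compound can be called stronger or weaker than another on this evidence.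

Compound 1 and compound 2 differ in a single place:
4-methylphenyl in place of 3-methylphenyl on an aromatic nitrogen
This change produced a 1.6-fold higher number from compound 1 to compound 2 (0.19 log units; within the scatter).

Compound 4, `Cc1ccc(-n2cc(-c3cccc(NS(=O)(=O)c4c[nH]c(=O)[nH]c4=O)c3)nn2)cc1`, has not yet been tested. It is built from compound 3 by exactly the same kind of change:
4-methylphenyl in place of 3-methylphenyl on an aromatic nitrogen
The surroundings of the change, as described above, are the same in both pairs. How the core of compound 3 differs from the core of compound 1 is not broken down here.

Because the matching step in the first pair gave a 1.6-fold higher number from compound 1 to compound 2 (0.19 log units; within the scatter), a step of similar size is expected here, namely a 1.4-fold higher number from compound 3 to compound 4 (0.15 log units; within the scatter). Since that earlier step was itself within the scatter, the expectation is loose. For compound 4 the estimated value in this assay is 5000 nM, expected to fall between 2500 nM and 10000 nM.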

Compound 4, half-maximal inhibitory concentration: 3630 nM
Compound 4: the middle estimate sits 1.4-fold (0.14 log units) above what was measured; measured number inside the range.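

Replacing 3-methylphenyl with 4-methylphenyl on the core of compound 3 gave a 1.0-fold higher number from compound 3 to compound 4 (0.01 log units; within the scatter) in this assay, so the two members of this pair cannot be told apart on this read-out. Set beside the first pair, the same change gives steps that agree as closely as measurements of this kind can show: the same change on two cores in this assay, a 1.6-fold higher number (0.19 log units; within the scatter) from compound 1 to compound 2 and a 1.0-fold higher number (0.01 log units; within the scatter) from compound 3 to compound 4, 1.5-fold (0.18 log units) apart, within the scatter of two such steps. On these two cores, then, the change carried over in the limited sense that neither step stood out from the scatter, but this does not show that the methyl position is without any influence, as steps this small could hide a modest effect, and two pairs in one cell assay are too few to set a rule for the series.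

From the compounds shown here alone, whether a bigger change on this phenyl ring, such as an amine or a carboxylic acid in place of the methyl, would move the number beyond the scatter remains open. Also open, going by these compounds, is whether the step between 3-methylphenyl and 4-methylphenyl would stay this small on a third core or in another cell line.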